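Little Change Expected from a Larger Sulfonyl Group

A few compounds are considered here, and "the series" means these few. Any claim that something is new, unique, unknown or untested is made for them only; others in the source may bear on it.

Measured in a functional assay on the whole organism for inhibition, with Rattus norvegicus as the target (a lower number here means that less compound is needed, a higher number that more compound is needed for the effect), as follows
Compound 1 `CCCCc1nc(SC)c(C(=O)C[S+]([O-])c2ccccc2)n1Cc1ccc(-c2ccccc2S(=O)(=O)NC(=O)NCc2ccccc2)cc1` gives 1.6 mg/kg
Compound 2 `CCc1nc(SC)c(C(=O)C[S+]([O-])c2ccccc2)n1Cc1ccc(-c2ccccc2S(=O)(=O)NC(=O)NCc2ccccc2)cc1` gives 2 mg/kg
Compound 3 `CCCCc1nc(SC)c(C(=O)CS(C)(=O)=O)n1Cc1ccc(-c2ccccc2S(=O)(=O)NC(=O)NCc2ccccc2)cc1` gives 1.7 mg/kg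

Compound 3 at 1.7 mg/kg lies within the scatter of both other compounds. Compound 4 `CCCCc1nc(SC)c(C(=O)CS(=O)(=O)c2ccc(F)cc2)n1Cc1ccc(-c2ccccc2S(=O)(=O)NC(=O)NCc2ccccc2)cc1` differs from it by 4-fluorophenyl in place of methyl on a sulfonyl sulfur in one place, 4-fluorophenyl in place of methyl on a sulfonyl sulfur. The nearest evidence is a 1.1-fold higher number from compound 1 to compound 3 (0.03 log units; within the scatter) where a group with a six-membered aromatic ring gave way to one without a ring on a saturated chain carbon bound to a carbonyl carbon. The other measured step of a 1.3-fold higher number from compound 1 to compound 2 (0.10 log units; within the scatter) lies elsewhere on the molecule and bears on this change very little. Neither step tests the fluorine. Both stayed within the scatter, so no step beyond it is expected in this assay in either direction. The estimated step is a 1.1-fold higher number from compound 3 to compound 4 (0.02 log units; within the scatter) and no more than scatter. Compound 4 is expected at 1.8 mg/kg within an estimated 0.8 mg/kg to 4 mg/kg as its range.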

Compound 4, dose for 50% inhibition: > 3 mg/kg
Compound 4: no number, only a limit; the forecaster's own chance of this, stated with the estimate: 3%; at least 1.6-fold (0.22 log units) between middle value and limit.
By their numbers in this assay, from the lowest: compounds 1, 3 and 2 (each within the scatter of the next). At a limit, above all of these: compound 4.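

In this assay compound 4 gives only a limit, not a number: the limit of > 3 mg/kg in this assay, at which 1 of the 4 values shown sits. Placing 4-fluorophenyl for methyl on the sulfonyl sulfur gives an at least 1.7-fold higher number from compound 3 to compound 4 (0.24 log units; that floor lies within the scatter), and the comparison at the saturated chain carbon bound to a carbonyl carbon gives an at least 1.8-fold higher number from compound 1 to compound 4 (0.27 log units; that floor lies within the scatter). Both are floors that lie within the scatter, so this change is the first at this position whose true size has no upper end, and a real loss is possible but not shown.

The compounds shown leave open whether the ring or its fluorine matters here. A plain phenylsulfonyl group on the same carbon would separate the two.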